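The compounds below may be only part of what the source reports. "The series", "measured", "known", "first", "only" and "open" are said of these compounds alone.

Going by the values given here, compound 2 (`COc1ccc(N(C)c2nc(C)nc3ccccc23)cc1`) gives 3 nM in a functional assay on A549 cells (Homo sapiens) for inhibition, read by MTT assay, with a stated time of 48 h (a lower number here means a stronger inhibitor, a higher number a weaker inhibitor), the lower of the two numbers measured so far, whereas compound 1 (`COc1ccc(N(C)c2nc(C)nc3ccccc23)cc1C(=O)OCC[Se]C#N`) gives 353 nM. The next structure, compound 3 (`COc1ccc(N(C)c2nc(C)nc3ccccc23)cc1OCCCCC[Se]C#N`), changes compound 2 as follows: a group of 9 heavy atoms (6 carbon, 1 nitrogen, 1 oxygen, 1 selenium; no ring) in place of a hydrogen atom, on an aromatic carbon. The entering group sits on an aromatic carbon, ortho to a methoxy group. Among the compounds with values here, only one measured step bears on this change, and it is large and beyond the scatter: a 120-fold lower number from compound 1 to compound 2 (2.07 log units; beyond the scatter). In that step, a hydrogen atom takes the place of a chain on an aromatic carbon. Within the data shown here, compound 3 goes the opposite way, from hydrogen to a chain, but its chain differs from that of compound 1, and no measurement yet tests it. A clear rise is therefore expected in this assay, somewhat smaller than that single step, with the expected change being a 33-fold higher number from compound 2 to compound 3 (1.52 log units; beyond the scatter). For compound 3 the estimated value is 100 nM, within an expected range of 15 nM to 600 nM.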

Compound 3, half-maximal inhibitory concentration: 2440 nM
Estimate against measurement, compound 3: 24-fold (1.39 log units) below, outside the stated range (above it).
By their numbers in this assay, from the lowest: compound 2; then compound 1; then compound 3.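

In this assay, a second chain on this aromatic carbon, ortho to a methoxy group, also raises the number, with an 810-fold higher number from compound 2 to compound 3 (2.91 log units; beyond the scatter), so hydrogen gives the lowest number of the three groups tested here. The two chains are not interchangeable at this carbon, since exchanging one for the other gives a 6.9-fold higher number from compound 1 to compound 3 (0.84 log units; beyond the scatter), a modest step but one beyond the scatter. No measurement shown here accounts for either step.

The compounds shown leave open which part of the chain governs these steps, as the two chains differ in both their link to the ring and their length. They also leave open how a small group such as an amine or a hydroxyl, or a shorter chain without selenium, would compare with hydrogen at this carbon.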